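Amine substituent changes on the shared core

The compounds below may be only part of what the source reports. "The series", "measured", "known", "first", "only" and "open" are said of these compounds alone.

Compound 1 `COc1ccc(/C=C\c2cc(OC)c(OC)c(OC)c2)cc1OCc1ccc(CN[C@H](C(=O)O)[C@H](C)O)cc1` reaches only the limit of a functional assay on MC-38 cells (Mus musculus) for antiproliferative activity, read by CCK-8 assay, with a stated time of 48 h (a higher number here means a weaker inhibitor, a lower number a stronger inhibitor), > 10000 nM. Compound 2 `COc1ccc(/C=C\c2cc(OC)c(OC)c(OC)c2)cc1OCc1ccc(CN2CCCCC2C(=O)O)cc1` gives 5400 nM in this assay. Compound 3 `COc1ccc(/C=C\c2cc(OC)c(OC)c(OC)c2)cc1OCc1ccc(CN2CC[C@H](O)C2)cc1` gives 7200 nM in this assay.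

Compound 1 therefore stands at the limit of > 10000 nM in this assay, at which 1 of the 3 values shown sits; no number exists for it, only the limit. Compound 4 `COc1ccc(/C=C\c2cc(OC)c(OC)c(OC)c2)cc1OCc1ccc(CNCCNC(C)=O)cc1` differs from compound 1 in one place: 2-acetamidoethyl in place of 1-carboxy-2-hydroxypropyl on an amine nitrogen. Two measured steps leave from the same point and the same group: an at least 1.8-fold lower number from compound 1 to compound 2 (0.26 log units; that floor lies within the scatter) and an at least 1.3-fold lower number from compound 1 to compound 3 (0.14 log units; that floor lies within the scatter). Both floors sit within the scatter, and a 1.3-fold higher number from compound 2 to compound 3 (0.12 log units; within the scatter) is also within the scatter. For the measured compounds named here, no step so far moves far beyond the limit, so a change of similar size is expected for compound 4, as an at least 1.2-fold lower number from compound 1 to compound 4 (0.09 log units; that floor lies within the scatter). Compound 4 is estimated at 8000 nM, ranging from 3000 nM to 20000 nM, with a fair chance that only the limit is reported.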

Compound 4, half-maximal inhibitory concentration: 1800 nM
The estimate for compound 4 lay 4.4-fold (0.65 log units) above the measured number; the whole stated range lies above it.
By their numbers in this assay, from the lowest: compound 4; then compounds 2 and 3 (each within the scatter of the next). At a limit, above all of these: compound 1.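

For the compounds shown here, on the amine nitrogen, 2-acetamidoethyl is the first group in this set to give steps beyond the scatter in this assay: an at least 5.5-fold lower number from compound 1 to compound 4 (0.74 log units; beyond the scatter), a 4.0-fold lower number from compound 3 to compound 4 (0.60 log units; beyond the scatter) and a 3.0-fold lower number from compound 2 to compound 4 (0.48 log units; beyond the scatter). An open chain alone does not account for this, since 1-carboxy-2-hydroxypropyl also has no ring, yet compound 1 gives only a limit: the limit of > 10000 nM in this assay, at which 1 of the 4 values shown sits.

Still open, as far as these compounds go, is which part of 2-acetamidoethyl carries the step, the amide or the ethyl chain. Also open, from the compounds shown here alone, is how a longer chain, or a carboxylic acid or primary amine in place of the acetamide, would read.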